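The compounds below may be only part of what the source reports. "The series", "measured", "known", "first", "only" and "open" are said of these compounds alone.

Series notes, growth inhibition.

Compound 1 `COc1ccc(CNCCCNS(=O)(=O)c2cc(C(F)(F)F)cc(C(F)(F)F)c2)cc1OC`: in a functional assay on MIA PaCa-2 cells (Homo sapiens) for inhibition, read by MTT assay, with a stated time of 72 h (a higher number here means a weaker inhibitor of growth, a lower number a stronger inhibitor of growth), compound 1 gives 2800 nM.
Compound 2 `COc1ccc(S(=O)(=O)NCCCCCCNCc2ccc(Br)cc2)cc1`: in this assay compound 2 gives 13000 nM.
Compound 3 `CCCCc1ccc(S(=O)(=O)NCCCCCCNCc2ccc(Br)cc2)cc1`: in this assay compound 3 gives 5700 nM.

Compound 3 stands second highest of the three numbers. Its nearest neighbour is compound 1, which shows a lower number, beyond the scatter; its furthest is compound 2, which shows a higher number, also beyond the scatter. Within the data shown here, the only single-point step measured so far is a 2.3-fold lower number from compound 2 to compound 3 (0.36 log units; beyond the scatter), butyl in place of methoxy on an aromatic carbon, a modest gain.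

Compound 4 `CC(C)c1ccc(S(=O)(=O)NCCCCCCNCc2ccc(Br)cc2)cc1` differs from compound 3 by isopropyl in place of butyl on an aromatic carbon. Among the measured compounds shown here, the step from compound 2 to compound 3 bears on it only indirectly: isopropyl, like butyl, carries no donor and no acceptor, but no measured step tells how a shorter chain at this place behaves. The number for compound 4 is therefore expected to sit close to that of compound 3, with a step of a 1.2-fold higher number from compound 3 to compound 4 (0.09 log units; within the scatter) in this assay, not beyond the scatter. For compound 4 the estimate in this assay is 7000 nM, with a range from 3500 nM to 14000 nM.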

Compound 4, concentration for 50% growth inhibition: 5730 nM
For compound 4 the middle estimate is 1.2-fold (0.09 log units) above the measured one; measured number inside the range.
By their numbers in this assay, from the lowest: compound 1; then compounds 3 and 4 (each within the scatter of the next); then compound 2.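

Working notes on this position, on the aromatic carbon para to a large group: in this assay, isopropyl in place of butyl leaves the number unchanged within the scatter, with a 1.0-fold higher number from compound 3 to compound 4 (0.00 log units; within the scatter). Isopropyl in place of methoxy gives a 2.3-fold lower number from compound 2 to compound 4 (0.36 log units; beyond the scatter), so the step seen with butyl is now matched by a second group of carbon only, and among compounds 2, 3 and 4 only the methoxy compound stands apart. No supporting evidence is available to explain either step.

The compounds shown leave open whether an amine, a carboxylic acid or a chain longer than butyl at this place would move the number beyond the scatter. They also leave open whether butyl and isopropyl would still read alike with chlorine in place of the bromine of the shared core.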